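Selenocyanate series on RKO cells: compound 1 to compound 3

The source may report more compounds than this note shows. Statements on the series, on what has been measured and on what is new or still open speak of the compounds shown alone.

Measured so far:
compound 1 `COc1ccc(N(C)c2nc(C)nc3ccccc23)cc1C(=O)OCC[Se]C#N` — 2390 nM
compound 2 `Cc1nc(N(C)c2ccc([Se]C#N)c(Cl)c2)c2ccccc2n1` — 11 nM

In a functional assay on RKO cells (Homo sapiens) for inhibition, read by MTT assay, with a stated time of 48 h (on this read-out lower numbers stand for stronger inhibition and higher numbers for weaker inhibition), compound 1 gives 2390 nM, the highest of the two numbers; its nearest neighbour is compound 2, which gives 11 nM, a gap that lies beyond the scatter. Going by the values given here, no step between compounds that differ in one place is available, so the two values show only that compound 2 sits far lower than compound 1.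

Compound 3 `COc1ccc(N(C)c2nc(C)nc3ccccc23)cc1OCCN` is still to be measured in this assay. It differs from compound 1 as follows: a group of 4 heavy atoms (2 carbon, 1 nitrogen, 1 oxygen; no ring) in place of a group of 8 heavy atoms (4 carbon, 1 nitrogen, 2 oxygen, 1 selenium; no ring), on an aromatic carbon. The group that leaves carries the selenium; the 2-aminoethoxy group that enters carries none. With only compound 1 and compound 2 as reference points, the step is expected to move toward a higher number, beyond the scatter. Compound 3 is estimated at 6000 nM (range 1200 nM to 30000 nM), an expected step of a 2.5-fold higher number from compound 1 to compound 3 (0.40 log units; beyond the scatter).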

Compound 3, half-maximal inhibitory concentration: 343 nM
Compound 3: middle estimate off by 17-fold (1.24 log units), on the high side; measured number below the stated range.
By their numbers in this assay, from the lowest: compound 2; then compound 3; then compound 1.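

At this aromatic carbon, ortho to a methoxy group, 2-aminoethoxy in place of the selenium-carrying group gives a 7.0-fold lower number from compound 1 to compound 3 (0.84 log units; beyond the scatter) in this assay. On this core, then, the group at this position need not carry selenium for the number to fall, and the ester-linked selenium chain is not the better of the two groups here. No measurement bearing on the cause of this step is at hand.

The change replaces the whole group at once, so the parts played by the amine, the ether oxygen, the ester carbonyl and the selenium stay unseparated. A 2-methoxyethoxy or 3-aminopropoxy chain on the same aromatic carbon would test the amine and the chain length, and a selenocyanate on a short ether chain there would test the selenium.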